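A Thiophene Swap on a Pair That Showed Nothing

The compounds below may be only part of what the source reports. "The series", "measured", "known", "first", "only" and "open" are said of these compounds alone.

Two compounds with a shared core have been run in an assay on isolated protein for inhibition of Indoleamine 2,3-dioxygenase 1 (Homo sapiens), read by spectrophotometry (on this read-out lower numbers stand for stronger inhibition and higher numbers for weaker inhibition), and both returned only a limit. Compound 1 `O/N=C(/Nc1ccccc1)c1ccc2occc2c1` gives in this assay a limit, > 30000 nM. Compound 2 `O/N=C(/NCc1cccc(Cl)c1)c1ccc2occc2c1` likewise gives in this assay a limit, > 30000 nM. Among the measured compounds shown here, compound 2 thus stands at the limit of > 30000 nM in this assay, at which 2 of the 2 values shown sit, and no step between measured compounds can be drawn from these two limits. Compound 3 `O/N=C(/NCc1cccs1)c1ccc2occc2c1` departs from compound 2 by thiophen-2-yl in place of 3-chlorophenyl on a saturated chain carbon bound to an amine nitrogen. Nothing measured here points to a change in either direction from this swap, so the step is expected to be none beyond the scatter, and compound 3 is expected to sit again at the limit of this assay more often than not. Compound 3 is estimated at 40000 nM, within a range of 12000 nM to 120000 nM. The expected step is a step that the limit leaves unreadable from compound 2 to compound 3.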

Compound 3, half-maximal inhibitory concentration: > 30000 nM
Compound 3: no number, only a limit; the forecaster's own chance of this, stated with the estimate: 75%; the middle value lies beyond the limit too.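

In this assay compound 3 gives only a limit, > 30000 nM, so no step can be read between compound 3 and either compound 1 or compound 2. The compounds shown leave open whether any group on the amine nitrogen of the shared core would give a measurable value.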